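A Larger Substituted Ring in Place of Phenyl

A few compounds are considered here, and "the series" means these few. Any claim that something is new, unique, unknown or untested is made for them only; others in the source may bear on it.

Measured so far:
compound 1 `COc1cc(-c2ccnc3cc(-c4cn(CO)c5ccccc45)nn23)cc(OC)c1OC`: 103 nM
compound 2 `COc1cc(-c2ccnc3cc(-c4ccccc4)nn23)cc(OC)c1OC`: 458 nM

In a functional assay on HeLa cells (Homo sapiens) for inhibition, read by CCK-8 assay, with a stated time of 48 h (on this read-out higher numbers stand for weaker inhibition and lower numbers for stronger inhibition), compound 2 gives 458 nM, the higher of the two numbers, while compound 1 gives 103 nM, a gap beyond the usual scatter. Compound 3 `COc1ccc(-c2cc3nccc(-c4cc(OC)c(OC)c(OC)c4)n3n2)cc1N` is not yet measured. It differs from compound 2 in one place: 3-amino-4-methoxyphenyl in place of phenyl on an aromatic carbon. Going by the values given here, no measured pair shows this change, so the expectation rests on the change alone: a larger group carrying a hydrogen-bond donor enters where a bare phenyl stood. In this assay the expected step is modest and toward a lower number, a 2.3-fold lower number from compound 2 to compound 3 (0.36 log units; beyond the scatter). Compound 3 is estimated at 200 nM, ranging from 60 nM to 700 nM.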

Compound 3, half-maximal inhibitory concentration: 283 nM
For compound 3 the middle estimate is 1.4-fold (0.15 log units) below the measured one; low and high end bracket the measured number.
By their numbers in this assay, from the lowest: compound 1; then compounds 3 and 2 (each within the scatter of the next).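

In this assay, 3-amino-4-methoxyphenyl in place of phenyl on an aromatic carbon gives a 1.6-fold lower number from compound 2 to compound 3 (0.21 log units; within the scatter), so the two numbers cannot be told apart. This position can therefore carry a larger ring with a hydrogen-bond donor and still give a reading that repeated measurement could not separate from that of the bare phenyl.

Going by these compounds, what a phenyl carrying only the amino group or only the methoxy group would give stays open, as does a carboxylic acid on that ring. Nothing reported with these compounds gives a reason for this result.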